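Replacing nitro with propanoylamino in compound 1

This account rests on a few compounds, and the source may have more. Where it says the series, first, only, none or still open, it means among the compounds named here.

Measured in a toxicity assay on Huh-7.5 cells (Homo sapiens) for inhibition, read by MTT assay, with a stated time of 96 h; on this read-out lower numbers stand for higher toxicity in this test and higher numbers for lower toxicity in this test:
- compound 1 `COc1ccc(NC(=O)c2ccc(OCCCN(C)C)c([N+](=O)[O-])c2)cc1`: 127000 nM
- compound 2 `CN(C)C1CCN(Cc2ccc(NC(=O)c3ccc(OCCCCl)c([N+](=O)[O-])c3)cc2C(F)(F)F)C1`: 5800 nM
- compound 3 `CC(C)Oc1ccc(C(=O)Nc2ccc(CN3CCN(C)CC3)c(C(F)(F)F)c2)cc1NC(=O)C(C)Br`: 8700 nM

Compound 1 holds the highest of the three numbers, at 127000 nM, and stands beyond the scatter from both others. Compound 2 gives 5800 nM and compound 3 gives 8700 nM, two values within the scatter of each other. Both differ from compound 1 in more than one place, so neither gap can be assigned to a single structural feature.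

The next compound is compound 4 `CCC(=O)Nc1cc(C(=O)Nc2ccc(OC)cc2)ccc1OCCCN(C)C`, which has propanoylamino in place of nitro on an aromatic carbon, ortho to a 3-(dimethylamino)propoxy group (propanoylamino in place of nitro on an aromatic carbon). The rest of the core of compound 1 is unchanged. Going by the values given here, no pair of measured compounds differs in one place, so this change has no direct precedent.

In this assay, the expectation is a small step toward a lower number, possibly none beyond the scatter. The closest reference is compound 1 at 127000 nM, and the estimate stays near it. The estimate corresponds to a 1.8-fold lower number from compound 1 to compound 4 (0.26 log units; within the scatter). For compound 4 the estimated value is 70000 nM, with an expected range from 20000 nM to 200000 nM.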

Compound 4, half-maximal cytotoxic concentration: 154000 nM
The estimate for compound 4 lay 2.2-fold (0.34 log units) below the measured number, within the range that was stated.
By their numbers in this assay, from the lowest: compounds 2 and 3 (each within the scatter of the next); then compounds 1 and 4 (each within the scatter of the next).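

Going by these compounds alone, the exchange of nitro for propanoylamino on this aromatic carbon, ortho to a 3-(dimethylamino)propoxy group, gives the first single-place comparison: in this assay it produces a 1.2-fold higher number from compound 1 to compound 4 (0.08 log units; within the scatter) and so leaves the read-out unchanged within the scatter. This pair therefore shows that the high number of compound 1 does not depend on nitro at this position, and that the position accepts a change from 3 heavy atoms to 5 heavy atoms, with a hydrogen-bond donor entering, without a step beyond the scatter. No measurement on these compounds gives a reason for this outcome.

Compound 2 and compound 3 each differ from compound 1 in more than one place, so the structural source of their separation from it remains unassigned. Still open, on these data alone, is whether a free amine, an acetylamino group or a longer acylamino chain at this position would also stay within the scatter, and whether propanoylamino in place of nitro would give the same result on the core of compound 2.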